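A few compounds are considered here, and "the series" means these few. Any claim that something is new, unique, unknown or untested is made for them only; others in the source may bear on it.

Of the compounds shown here, three have been read in an ADME assay on Vero cells (Chlorocebus sabaeus) for cytotoxicity, read by neutral red uptake (on this read-out lower numbers stand for higher toxicity in this test and higher numbers for lower toxicity in this test), and none of them has given a number. Compound 1 (`CC1(C)CC(=O)C(=C/C=C/c2ccccc2)C(=O)C1`) gives > 18.7 uM, which is a limit of the assay. Compound 2 (`CC1(C)CC(=O)C(=CC=C(c2ccccc2)c2ccccc2)C(=O)C1`) gives > 14.4 uM, also a limit. Compound 3 (`O=C1CCC(=O)C1=C/C=C/c1ccccc1`) gives > 22.4 uM, again a limit. Compound 3 therefore has no measured toxic concentration, and the same is true of the other two compounds. Among the measured compounds shown here, no toxicity has been reached in any of the three, so the data hold no measured step between compounds.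

Compound 4 (`O=C1CCC(=O)C1=C/C=C/c1ccc(Br)cc1`) is compound 3 with one change on the aromatic ring: bromo in place of hydrogen on an aromatic carbon. In words, this is bromo in place of hydrogen on an aromatic carbon. For the measured compounds named here, with no measured step to draw on, the expectation rests on compound 3 and its limit of > 22.4 uM. No change beyond the usual scatter is expected in this assay, and the likeliest report is another limit. The expected change, an at least 1.4-fold lower number from compound 3 to compound 4 (0.14 log units; that floor lies within the scatter), is an estimate and is small. For compound 4 the estimated half-maximal toxic concentration is 16 uM, with an expected range of 8 uM to 26 uM.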

Compound 4, half-maximal toxic concentration: > 16.3 uM
Compound 4: a limit, no number; the forecaster's own chance of this, stated with the estimate: 75%; middle value at least 1.0-fold (0.00 log units) away from the limit.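

Compound 3 and compound 4 both stand as limits in this assay, so no step can be read between them, and bromo in place of hydrogen on an aromatic carbon has no readable size. The compounds shown leave open at what concentration any of them would reach a half-maximal toxic effect in this assay.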